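Notes on a ring-nitrogen substituent swap, two compounds measured

This account rests on a few compounds, and the source may have more. Where it says the series, first, only, none or still open, it means among the compounds named here.

Measured so far, in a functional assay on MDA-MB-231 cells (Homo sapiens) for inhibition, read by sulforhodamine B assay, tested at 10 uM; on this read-out lower numbers stand for less inhibition and higher numbers for more inhibition at the one concentration tested (going by the name of the read-out):
- compound 1 `CN1CCN(c2ccc(C3=NN(S(=O)(=O)c4ccc(OC(F)(F)F)cc4)C(c4ccc(N(C)C)cc4)C3)cc2)CC1` gives 10.6%
- compound 2 `C=C(C)C(=O)N1N=C(c2ccc(-n3ccnc3)cc2)CC1c1ccc(N(C)C)cc1` gives 4.3%

Both numbers are small, and the gap between compound 2 and compound 1 lies within the usual scatter of repeated measurements, so the two cannot be told apart; neither is set above or below the other. Among the compounds with values here, no step between measured compounds that differ in a single place is available, so nothing about the ring-nitrogen substituent can yet be read off directly.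

Compound 3 `Cc1ccc(S(=O)(=O)N2N=C(c3ccc(-n4ccnc4)cc3)CC2c2ccc(N(C)C)cc2)cc1` is not yet measured. It differs from compound 2 in one place: (4-methylphenyl)sulfonyl in place of (1-methylethenyl)carbonyl on an amine nitrogen in a ring. Compound 1 also carries a sulfonyl group on that amine nitrogen and gives a small number, so no step beyond the scatter is expected; the expected step of a number 4.7 percentage points higher from compound 2 to compound 3 (within the scatter) is small and within the scatter. Compound 3 is estimated at 9% in this assay, with a range from 0% to 25%.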

Compound 3, a percentage reported as inhibition, at one concentration (the size of the read-out at that concentration, not a potency): 50.8%
Compound 3: the middle estimate sits 41.8 percentage points below what was measured, outside the stated range (above it).
By their numbers in this assay, from the lowest: compounds 2 and 1 (each within the scatter of the next); then compound 3.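

In this assay, within the data shown here, the substituent on the amine nitrogen in the ring gives the first single-place change, and the position proves sensitive to it: (4-methylphenyl)sulfonyl in place of (1-methylethenyl)carbonyl gives a number 46.5 percentage points higher from compound 2 to compound 3 (beyond the scatter). The change alters two things at once, replacing the carbonyl link with a sulfonyl link and the 1-methylethenyl part with a six-membered aromatic ring of carbon only, so the step belongs to the whole group rather than to either part. No available evidence explains the size of this step.

As far as these compounds go, it remains open whether the step follows the sulfonyl link or the aromatic ring; a 4-methylbenzoyl group and a methylsulfonyl group on the same nitrogen would separate the two. From the compounds shown here alone, it is also open whether a step of this size holds when other parts of the shared core change.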